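The compounds below may be only part of what the source reports. "The series", "measured", "known", "first", "only" and "open" are said of these compounds alone.

Of the compounds shown here, three have been measured so far, all built on a shared core with a second aromatic ring hung on an amide-type nitrogen. Compound 1 `O=C(Nc1ccc(Oc2ccc(-c3nccs3)cc2)cc1)Nc1ccc(Cl)c([N+](=O)[O-])c1` carries a 4-chloro-3-nitrophenyl on that nitrogen, though its core differs from the others in one ring; in a functional assay on MDA-MB-231 cells (Homo sapiens) for inhibition, read by MTT assay and WST assay, with a stated time of 72 h, tested at 10 uM (on this read-out lower numbers stand for less inhibition of growth and higher numbers for more inhibition of growth at the one concentration tested), compound 1 gives 72.8%. Compound 2 `O=C(Nc1ccc(Cl)cc1)Nc1ccc(Oc2ccc(-c3ncc[nH]3)cc2)cc1` carries a chlorophenyl there; in this assay compound 2 gives 47.6%. Compound 3 `O=C(Nc1ccccc1)Nc1ccc(Oc2ccc(-c3ncc[nH]3)cc2)cc1` carries a plain phenyl; in this assay compound 3 gives 11.4%, the lowest of the three numbers. Going by the values given here, the only measured step that touches compound 3 is a number 36.2 percentage points lower from compound 2 to compound 3 (beyond the scatter), which is well beyond the scatter and shows how much is lost when the chloro is taken away.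

Compound 4 `O=C(Nc1ccc(Oc2ccc(-c3ncc[nH]3)cc2)cc1)Nc1ccc(Cl)c([N+](=O)[O-])c1` is the next member. Its difference from compound 3 is 4-chloro-3-nitrophenyl in place of phenyl on an amide-type nitrogen. The step that bears on this is a number 36.2 percentage points lower from compound 2 to compound 3 (beyond the scatter), read in reverse, since putting a chloro back should undo that loss. Among the compounds with values here, compound 1, which carries the same 4-chloro-3-nitrophenyl on a slightly different core, reaches 72.8%, but no single-change step links it to compound 3. A large rise in this assay is therefore expected, roughly a number 46.6 percentage points higher from compound 3 to compound 4 (beyond the scatter). Compound 4 is estimated at 58%, with a range from 40% to 78%.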

Compound 4, percent growth inhibition at one concentration: 3.36%
Estimate against measurement, compound 4: 54.6 percentage points above; measured number below the stated range.
By their numbers in this assay, from the lowest: compounds 4 and 3 (each within the scatter of the next); then compound 2; then compound 1.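

Placing a nitro on the chlorophenyl of compound 2 does not build on the gain that the chloro gave in this assay: the change gives a number 44.2 percentage points lower from compound 2 to compound 4 (beyond the scatter), and the full 4-chloro-3-nitrophenyl in place of phenyl on the amide-type nitrogen gives only a number 8 percentage points lower from compound 3 to compound 4 (within the scatter), so with this core the added nitro cancels what the chloro alone brought. The same 4-chloro-3-nitrophenyl is not poor in every setting, since 1H-imidazol-2-yl in place of 1,3-thiazol-2-yl gives a number 69.4 percentage points lower from compound 1 to compound 4 (beyond the scatter), which means that what this group does on the nitrogen depends on the rest of the molecule. Nothing available here explains either reversal, so the reason for them remains unknown.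

As far as these compounds go, it remains open whether the loss belongs to the nitro itself, which a phenyl carrying a nitro without the chloro, or an amine or a nitrile in the nitro's place, could help to separate. From the compounds shown here alone, it is also open whether the plain chlorophenyl and the plain phenyl would show the same large difference on the core of compound 1.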